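Replacing a Cyclic Ether with a Branched Alkyl Amide

A few compounds are considered here, and "the series" means these few. Any claim that something is new, unique, unknown or untested is made for them only; others in the source may bear on it.

Compound 3 `COc1cc2nccc(Oc3ccc(Nc4nn(C)cc4C(=O)NCC4CCCO4)cc3)c2cc1C(N)=O` belongs to a small set of three measured compounds sharing one core. In a functional assay on BaF3 cells (Mus musculus) for antiproliferative activity, read by CCK-8 assay and cell counting, with a stated time of 76 h (a lower number here means a stronger inhibitor, a higher number a weaker inhibitor), compound 3 gives only a limit, > 10000 nM. Compound 1 `COc1cc2nccc(Oc3ccc(Nc4nn(C)cc4C(=O)NOCc4ccccc4)cc3)c2cc1C(N)=O` likewise gives only a limit in this assay, > 10000 nM. Compound 2 `COc1cc2nccc(Oc3ccc(Nc4nn(C)cc4C(=O)Nc4cccc(F)c4)cc3)c2cc1C(N)=O` gives a number in this assay, 4480 nM. The two steps that touch compound 3 are an at least 2.2-fold higher number from compound 2 to compound 3 (0.34 log units; beyond the scatter) and a step that the two limits leave unreadable from compound 1 to compound 3; the second cannot be read because of the limit of > 10000 nM in this assay, at which 2 of the 3 values shown sit.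

Compound 4 `COc1cc2nccc(Oc3ccc(Nc4nn(C)cc4C(=O)NCC(C)C)cc3)c2cc1C(N)=O` differs from compound 3 by the change (isopropyl in place of oxolan-2-yl on a saturated chain carbon bound to an amide-type nitrogen). For the measured compounds named here, no measured step swaps one saturated group for another on that carbon, so no direct comparison exists. What is known is that both compounds with a saturated chain on the amide-type nitrogen, compound 1 and compound 3, reach only the limit, while the aryl amide compound 2 yields a number. Compound 4 is therefore expected to remain at the weak end, with an estimated value of 15000 nM and a range from 5000 nM to 50000 nM. The expected step is a step that the limit leaves unreadable from compound 3 to compound 4.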

Compound 4, half-maximal inhibitory concentration: > 10000 nM
Compound 4 gave a limit, no number (the forecaster's own chance of this, stated with the estimate: 70%); the middle value lies beyond the limit too.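

With isobutyl on the amide-type nitrogen, compound 4 carries a saturated group that has neither a ring nor a hetero atom, yet in this assay it ends at the same limit as compound 1 and compound 3. Within these four compounds, a number therefore appears only with the 3-fluorophenyl amide, and isobutyl in place of 3-fluorophenyl gives an at least 2.2-fold higher number from compound 2 to compound 4 (0.34 log units; beyond the scatter). The steps from compound 3 and compound 1 to compound 4 cannot be read: the limit of > 10000 nM in this assay, at which 3 of the 4 values shown sit.

As far as these compounds go, whether oxolan-2-yl or isopropyl is the better group on the saturated chain carbon stays open, as does how far compound 1, compound 3 and compound 4 each lie past the limit. Also open, from the compounds shown here alone, is whether a chain ending in an amine or a carboxylic acid on the amide-type nitrogen would give a number.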